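This account rests on a few compounds, and the source may have more. Where it says the series, first, only, none or still open, it means among the compounds named here.

Working notes on the series.

Compound 1 `CC(C)(C)c1nnc(-c2ccc(N3CCC(Oc4ccccc4C(F)(F)F)CC3)nn2)o1` is one of two measured members; in an assay on microsomes from liver for inhibition of acyl-CoA desaturase 1 (Rattus norvegicus) (on this read-out lower numbers stand for stronger inhibition and higher numbers for weaker inhibition), compound 1 gives 980 nM, the highest of the two numbers recorded. The other measured member, compound 2 `c1cn(-c2ccc(N3CCC(Oc4ccc5c(c4)CCC5)CC3)nn2)cn1`, gives 62 nM in this assay, a lower number and well clear of compound 1. Going by the values given here, no single-point step between the two is available, since they differ in more than one place, so their values are read only side by side.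

The step under consideration leads from compound 1 to compound 3 `O=C(NCCC1CC1)c1ccc(N2CCC(Oc3ccccc3C(F)(F)F)CC2)nn1`. The structural change is (2-cyclopropylethyl)carbamoyl in place of 5-(tert-butyl)-1,3,4-oxadiazol-2-yl on an aromatic carbon. The shared core of compound 1 and the 2-(trifluoromethyl)phenoxy-piperidine part are kept; only the group on the aromatic carbon of the core changes, the 5-(tert-butyl)-1,3,4-oxadiazol-2-yl leaving and the (2-cyclopropylethyl)carbamoyl entering.

Among the compounds with values here, no measured pair shows this exact change, so the step of a 2.2-fold lower number from compound 1 to compound 3 (0.34 log units; beyond the scatter) in this assay is an expectation only, a modest move toward a lower number that may not exceed the scatter. Compound 3 is accordingly estimated at 450 nM in this assay, within a range from 120 nM to 1800 nM.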

Compound 3, half-maximal inhibitory concentration: 14 nM
Compound 3: the middle estimate sits 32-fold (1.51 log units) above what was measured; measured number below the stated range.
By their numbers in this assay, from the lowest: compound 3; then compound 2; then compound 1.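

Going by these compounds alone, the aromatic carbon of the shared core, para to a large group, proves highly sensitive in this assay: with the 2-(trifluoromethyl)phenoxy-piperidine part kept, (2-cyclopropylethyl)carbamoyl in place of 5-(tert-butyl)-1,3,4-oxadiazol-2-yl gives a 70-fold lower number from compound 1 to compound 3 (1.85 log units; beyond the scatter) as the first step that can be assigned to one place. The exchange alters several counted features together, with one five-membered aromatic ring with 3 hetero atoms, 0 hydrogen-bond donors and 3 hydrogen-bond acceptors leaving, while one three-membered non-aromatic ring of carbon only, 1 hydrogen-bond donor and 1 hydrogen-bond acceptor enter. Nothing available bears on which of these features accounts for the size of the step.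

The compounds shown do not separate the carbamoyl from the 2-cyclopropylethyl part, a question that a methylcarbamoyl, a carboxylic acid or a longer alkyl chain on the carbamoyl nitrogen at this carbon would address. Going by these compounds, it also remains open whether the same exchange gives a comparable step with another group in place of the 2-(trifluoromethyl)phenoxy, such as an unsubstituted phenoxy.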